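From pyridin-3-yl to phenyl on a carbonyl carbon

The compounds below may be only part of what the source reports. "The series", "measured", "known", "first", "only" and "open" are said of these compounds alone.

In a physicochemical assay for lipophilicity, using the shake flask method, in phosphate buffer, measured as octanol-water partition, with a stated time of 30 min, at pH 7.4 (on this read-out lower numbers stand for lower lipophilicity and higher numbers for higher lipophilicity), compound 1 `C[C@@H]1CC(=O)N(c2cnc(NCc3c(F)ccc4c3CCO4)n3cnnc23)C1` gives 1.8 and compound 2 `O=C(Nc1cnc(NCc2c(F)ccc3c2CCO3)n2cnnc12)c1cccnc1` gives 2 as its reading, so these two sit within the usual scatter of each other. Among the measured compounds shown here, the only measured step is a number 0.20 log units higher from compound 1 to compound 2 (within the scatter) and it exchanges different groups, so it offers little guidance here. Compound 3 `O=C(Nc1cnc(NCc2c(F)ccc3c2CCO3)n2cnnc12)c1ccccc1` carries one exchange: phenyl in place of pyridin-3-yl on a carbonyl carbon with phenyl in place of pyridin-3-yl on a carbonyl carbon. For the measured compounds named here, no measured step makes this exchange, so the estimate rests on the structural change alone. Expected in this assay is an upward step beyond the scatter, estimated as a number 0.80 log units higher from compound 2 to compound 3 (beyond the scatter) for this exchange. For compound 3 the estimated value is 2.8 with an expected range from 2.3 to 3.3 on this scale.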

Compound 3, distribution coefficient: 3
Beside the measured number, compound 3's estimate is 0.20 log units below it; the measured number falls inside the stated range.
By their numbers in this assay, from the lowest: compounds 1 and 2 (each within the scatter of the next); then compound 3.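

In this assay the ring on this carbonyl carbon clearly counts: phenyl in place of pyridin-3-yl gives a number 1.00 log units higher from compound 2 to compound 3 (beyond the scatter) for the exchange of one ring nitrogen for carbon. Benzamido in place of 4-methyl-2-oxopyrrolidin-1-yl on an aromatic carbon gives a number 1.20 log units higher from compound 1 to compound 3 (beyond the scatter) while the ((pyridin-3-yl)carbonyl)amino group of compound 2 left it within the scatter of compound 1. No measurement at hand accounts for the size of this step. Still open, going by these compounds, is how the reading would respond to an amine or a carboxylic acid on the phenyl ring, or to cyclohexyl on the carbonyl carbon.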